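Removing a Chlorine from a Weakly Antiproliferative Spiro Compound

The compounds below may be only part of what the source reports. "The series", "measured", "known", "first", "only" and "open" are said of these compounds alone.

So far, two compounds have been measured in a functional assay on MCF7 cells (Homo sapiens) for antiproliferative activity, read by MTT assay, with a stated time of 48 h; on this read-out higher numbers stand for weaker inhibition and lower numbers for stronger inhibition:

Compound 1 `O=C1Nc2ccccc2[C@]12N[C@H](c1ccccc1)[C@H](c1cccs1)[C@@]21CCc2c([nH]c3ccccc23)C1=O`: 15000 nM
Compound 2 `COc1ccc([C@H]2[C@@H](c3ccccc3)N[C@@]3(C(=O)Nc4ccccc43)[C@]23CCc2c([nH]c4ccc(Cl)cc24)C3=O)cc1`: 19000 nM

Compound 2 stands at the highest of the two numbers, but compound 1 sits so close that the gap between them lies within the scatter of repeated measurements, so no order can be read from the pair. The two also differ from each other in more than one place, so no single change is isolated among the measured compounds.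

Compound 3 `COc1ccc([C@H]2[C@@H](c3ccccc3)N[C@@]3(C(=O)Nc4ccccc43)[C@]23CCc2c([nH]c4ccccc24)C3=O)cc1` differs from compound 2 in one place only: hydrogen in place of chloro on an aromatic carbon, on an aromatic carbon of a six-membered aromatic ring of carbon only, part of a fused or bridged system of six rings, meta to a fused ring and para to a fused ring. With both measured compounds giving weak numbers of similar size, the step from compound 2 to compound 3 in this assay is expected to be a 1.1-fold lower number from compound 2 to compound 3 (0.05 log units; within the scatter), nothing beyond the scatter in either direction. Compound 3 is therefore estimated at 17000 nM, within a range from 7000 nM to 40000 nM.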

Compound 3, half-maximal inhibitory concentration: 17000 nM
Compound 3: the middle estimate sits on the measured number at the digits printed; measured number inside the range.
By their numbers in this assay, from the lowest: compounds 1, 3 and 2 (each within the scatter of the next).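

In this assay, going by these compounds alone, hydrogen in place of chloro on the aromatic carbon, meta to a fused ring and para to a fused ring, gives a 1.1-fold lower number from compound 2 to compound 3 (0.05 log units; within the scatter), the first comparison in which only this position differs, and at this position the two groups cannot be told apart. On a saturated ring carbon, 4-methoxyphenyl in place of thiophen-2-yl gives a 1.1-fold higher number from compound 1 to compound 3 (0.05 log units; within the scatter), so these two groups cannot be told apart in this assay either. Nothing available bears on why these numbers lie so close.

Open, going by these compounds, is whether an amine or a carboxylic acid on that aromatic carbon would give a number beyond the scatter. Also open, on these data alone, is whether a pyridine ring or a longer chain on the saturated ring carbon would do so.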